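The source may hold more compounds than are shown below. What is called first, only, known or untested is meant among the compounds shown, and "the series" means these compounds.

Working notes on the series in an ADME assay on cells (Hepatocyte, Mus musculus) for metabolic stability; on this read-out lower numbers stand for a shorter-lived compound and higher numbers for a longer-lived compound.

Compound 1, `O=C(OC1CCC(CN2CCN(c3cc(=O)c4cc(C(F)(F)F)cc([N+](=O)[O-])c4s3)CC2)CC1)c1ccccc1`, gives 0.903 h in this assay. Compound 2, `O=C(NC1CCC(CN2CCN(c3cc(=O)c4cc(C(F)(F)F)cc([N+](=O)[O-])c4s3)CC2)CC1)c1ccccc1`, returns only a limit in this assay, > 1.55 h, as does the line (the limit of > 1.55 h in this assay, at which 1 of the 3 values shown sits). Compound 3, `O=C(OC1CCC(CN2CCN(c3cc(=O)c4cc(C(F)(F)F)cc([N+](=O)[O-])c4s3)CC2)CC1)c1ccncc1`, gives 0.0817 h in this assay. Among the numbers shown, compound 3 stands lowest; its nearest neighbour is compound 1, and the gap is an 11-fold lower number from compound 1 to compound 3 (1.04 log units; beyond the scatter), read in the forward direction. Against compound 2 the separation is an at least 18-fold lower number from compound 2 to compound 3 (1.27 log units; beyond the scatter), while the step of an at least 1.7-fold higher number from compound 1 to compound 2 (0.23 log units; that floor lies within the scatter) carries no weight beyond the scatter.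

Compound 4, `Cc1ccc(C(=O)OC2CCC(CN3CCN(c4cc(=O)c5cc(C(F)(F)F)cc([N+](=O)[O-])c5s4)CC3)CC2)cc1`, is not yet measured. Its difference from compound 3 is 4-methylphenyl in place of pyridin-4-yl on a carbonyl carbon. The measured step that bears on it is the one in which pyridin-4-yl replaced phenyl on the carbonyl carbon, an 11-fold lower number from compound 1 to compound 3 (1.04 log units; beyond the scatter), a large fall. For the measured compounds named here, the change to compound 4 runs the other way, removing pyridin-4-yl and putting an all-carbon ring back in its place, so a large rise in this assay is expected, of roughly the size seen before; no measured step speaks to the added methyl.

The expected step is a 9.8-fold higher number from compound 3 to compound 4 (0.99 log units; beyond the scatter). Compound 4 is estimated at 0.8 h, with a range from 0.3 h to 1.6 h.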

Compound 4, half-life: 0.202 h
Compound 4: middle estimate off by 4.0-fold (0.60 log units), on the high side; measured number outside the range, below it.
By their numbers in this assay, from the lowest: compound 3; then compound 4; then compound 1. At a limit, above all of these: compound 2.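

For the compounds shown here, the added methyl alone matters in this assay: a 4.5-fold lower number from compound 1 to compound 4 (0.65 log units; beyond the scatter), a change that the earlier compounds left unaddressed, so this aromatic ring of the series does not tolerate every substitution without a change in the read-out. The all-carbon ring therefore does not by itself restore the number lost with pyridin-4-yl on the carbonyl carbon, since the step to 4-methylphenyl is only a 2.5-fold higher number from compound 3 to compound 4 (0.39 log units; beyond the scatter), and compound 4 sits nearer to compound 3 than the phenyl of compound 1 would have suggested. The gap to the benzamido compound also stays wide, an at least 7.6-fold lower number from compound 2 to compound 4 (0.88 log units; beyond the scatter), and this step is a floor, since compound 2 is held only as a limit: the limit of > 1.55 h in this assay, at which 1 of the 4 values shown sits.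

Still open, on these data alone, is whether a 4-chlorophenyl or a 4-methoxyphenyl on the same carbonyl carbon would read like compound 1 or like compound 4, and whether 4-methylphenyl would cost as much on the benzamido side of the series. Nothing shown gives a cause for any of these steps.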